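Swapping a pyridinyl tail for a methoxy tail on a sulfonamide

The source may hold more compounds than are shown below. What is called first, only, known or untested is meant among the compounds shown, and "the series" means these compounds.

Measured compounds:
Compound 1, `CC(=O)SCC(=O)c1ccc(NS(=O)(=O)c2ccc3c(c2)COOC3)nc1`: 2000 nM
Compound 2, `CC(=O)SCC(=O)c1ccc(NS(=O)(=O)c2ccc(OCCCc3ccccn3)cc2)nc1`: "not determined" (no result reported)
Compound 3, `COc1cccc(S(=O)(=O)Nc2ccc(C(=O)CSC(C)=O)cn2)c1`: "not determined" (no result reported)

Three compounds share a core in which a sulfonamide joins an aromatic ring to a pyridine bearing a thioester side chain. In a functional assay on U226 cells (Homo sapiens) for cytotoxicity (on this read-out higher numbers stand for an effect only at larger amounts of compound and lower numbers for an effect already at smaller amounts), compound 1 gives 2000 nM. In the same assay compound 2 gives "not determined" (no result reported) and compound 3 gives "not determined" (no result reported), so compound 2 has no single number in this assay, compound 3 is a further entry without one, and compound 2 stands nowhere on the measured scale; only compound 1 anchors the series.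

Compound 4, `COCCCOc1ccc(S(=O)(=O)Nc2ccc(C(=O)CSC(C)=O)cn2)cc1`, is the next step from compound 2. The change is methoxy in place of pyridin-2-yl on a saturated chain carbon, three bonds along the chain from an oxygen on an aromatic ring. Among the compounds with values here, with no measured pair between compound 2 and compound 4, no step size can be computed; the expectation for this assay is a step of no clear direction and not beyond the usual scatter, though with wide uncertainty.

Compound 4 is therefore expected to give about 2000 nM in this assay, within a range from 400 nM to 10000 nM.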

Compound 4, half-maximal effective concentration: 29000 nM
Compound 4: middle estimate off by 15-fold (1.16 log units), on the low side, and the stated range ends below it.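

In this assay compound 4 gives 29000 nM but compound 2 has no single number, so no step can be read between them. The compounds shown leave open what exchanging pyridin-2-yl for methoxy does on this read-out. Nothing given here accounts for the value of compound 4.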